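The source may hold more compounds than are shown below. What is called first, only, known or untested is meant among the compounds shown, and "the series" means these compounds.

Compound 1, `Cc1ccc(C(=O)NCc2ccc(CNS(=O)(=O)c3ccc(C)cc3)cc2)cc1`, gives 1000 nM in an assay on MDA-MB-231 cells for binding affinity to C-X-C chemokine receptor type 4 (Homo sapiens), read by immunofluorescence and microscopy, with stated times of 10 min and 30 min (a lower number here means that less compound is needed, a higher number that more compound is needed for the effect), the higher of the two numbers measured in this series. Compound 2, `O=C(NCc1ccc(CNS(=O)(=O)c2ccccc2)cc1)c1ccncc1`, gives 10 nM in this assay, and these two compounds differ from one another in more than one place, so the pair shows only that a wide gap separates their two values and says nothing about any single change. Compound 3, `Cc1ccc(S(=O)(=O)NCc2ccc(CNC(=O)c3cccc(Cl)c3)cc2)cc1`, has not yet been measured in this assay. It differs from compound 1 in one place: 3-chlorophenyl in place of 4-methylphenyl on a carbonyl carbon. Going by the values given here, nothing among the measured compounds isolates this change, so the expectation for compound 3 rests on compound 1 alone. The step from compound 1 is expected to be small, with a 1.7-fold lower number from compound 1 to compound 3 (0.22 log units; within the scatter) lying within or only slightly beyond the usual scatter, and in no direction that can be fixed from what is known. On that basis compound 3 is estimated to give 600 nM, with a range from 100 nM to 3000 nM in this assay.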

Compound 3, effective concentration (reported as EC, without a stated level of effect): 100 nM
Compound 3: middle estimate off by 6.0-fold (0.78 log units), on the high side; the measured number falls inside the stated range.
By their numbers in this assay, from the lowest: compound 2; then compound 3; then compound 1.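

In this assay, placing 3-chlorophenyl in place of 4-methylphenyl on the carbonyl carbon gives a 10-fold lower number from compound 1 to compound 3 (1.00 log units; beyond the scatter) and shows that this position is not silent: exchanging one aryl group for another can move the number beyond the scatter. The step comes with no change in the counts of heavy atoms, hydrogen-bond donors or hydrogen-bond acceptors, and each group holds one six-membered aromatic ring of carbon only. No measurement at hand explains the step. The compounds shown do not separate the gain of the chlorine from the loss of the methyl, as a single exchange changes both at once. On these data alone, how a plain phenyl, or a bromine or a nitrile in place of the chlorine, would read at this carbonyl carbon also remains open.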